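A few compounds are considered here, and "the series" means these few. Any claim that something is new, unique, unknown or untested is made for them only; others in the source may bear on it.

Among the compounds with values here, compound 2 `CC(=O)c1cccc(NC(=O)Nc2ccc(C)c(NC(=O)c3ccccc3)c2)c1` is the only compound here with a proper number in a functional assay on A375P cells (Homo sapiens) for antiproliferative activity; on this read-out higher numbers stand for weaker inhibition and lower numbers for stronger inhibition: compound 2 gives 9800 nM. Compound 1 `Cc1ccc(NC(=O)Nc2ccc(C)c(NC(=O)c3ccccc3)c2)cc1C` is related to it by a single change. In this assay compound 1 reaches only a limit, > 30000 nM. One of the two values shown therefore sits at the limit (the limit of > 30000 nM in this assay, at which 1 of the 2 values shown sits). Going from compound 1 to compound 2, the number falls by an at least 3.0-fold lower number from compound 1 to compound 2 (0.48 log units; beyond the scatter), which is more than the usual scatter, although its true size is unknown because compound 1 only gave a limit.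

Compound 3 `Cc1ccc(NC(=O)Nc2ccc3c(c2)OCCO3)cc1NC(=O)c1ccccc1` is not yet measured. It differs from compound 2 in 2,3-dihydro-1,4-benzodioxin-6-yl in place of 3-acetylphenyl on an amide-type nitrogen. Within the data shown here, the only measured step concerns the same position on the shared core, and it shows that what sits there can shift the number beyond the scatter. The group entering compound 3 resembles neither of the groups already tried, so the direction cannot be read from that step. A small step in this assay is expected, most likely within the scatter, in either direction. This amounts to an expected step of a 1.0-fold higher number from compound 2 to compound 3 (0.01 log units; within the scatter). Compound 3 is accordingly estimated at 10000 nM, with a range from 3000 nM to 30000 nM.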

Compound 3, half-maximal inhibitory concentration: > 30000 nM
Compound 3: no number, only a limit; the forecaster's own chance of this, stated with the estimate: 30%; middle value at least 3.0-fold (0.47 log units) from the limit.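

In this assay, replacing 3-acetylphenyl with 2,3-dihydro-1,4-benzodioxin-6-yl on the amide-type nitrogen gives an at least 3.0-fold higher number from compound 2 to compound 3 (0.48 log units; beyond the scatter). A second, quite different group at this position therefore also gives a weaker result than 3-acetylphenyl, and compound 2 is the most active of the three compounds, although only by a margin of unknown size. The step from compound 1 to compound 3 cannot be read, and the picture at this position so far rests more on limits than on true numbers: the limit of > 30000 nM in this assay, at which 2 of the 3 values shown sit.

The compounds shown leave open whether the acetyl group itself matters, which a phenyl ring carrying a carboxylic acid, an amine or a nitrile in its place could help to test. They also leave open how far the true numbers of compound 1 and compound 3 lie from that of compound 2, and whether any group at this position can give much stronger inhibition than 3-acetylphenyl does.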